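Extending the amine side chain with a phenoxy-bearing group

The compounds below may be only part of what the source reports. "The series", "measured", "known", "first", "only" and "open" are said of these compounds alone.

Measured so far:
Compound 1, `CN(C)CCN(C)CCCN1C(=O)CSC1c1cc(C(C)(C)C)c(O)c(C(C)(C)C)c1`: 1700 nM
Compound 2, `CN(CCCN1C(=O)CSC1c1cc(C(C)(C)C)c(O)c(C(C)(C)C)c1)Cc1ccccc1`: 600 nM
Compound 3, `CN(C)CCCN1C(=O)CSC1c1cc(C(C)(C)C)c(O)c(C(C)(C)C)c1`: 1500 nM

In a functional assay on aorta for inhibition of Voltage-dependent L-type calcium channel subunit alpha-1C (Rattus norvegicus) (on this read-out higher numbers stand for weaker inhibition and lower numbers for stronger inhibition), compound 3 stands second highest of the three numbers. Its nearest neighbour is compound 1, whose value differs by a 1.1-fold lower number from compound 1 to compound 3 (0.05 log units; within the scatter), a gap within the scatter; compound 2 lies furthest away, by a 2.5-fold higher number from compound 2 to compound 3 (0.40 log units; beyond the scatter), a gap beyond the scatter.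

Compound 4, `CN(CCCN1C(=O)CSC1c1cc(C(C)(C)C)c(O)c(C(C)(C)C)c1)CC(O)COc1ccccc1`, is not yet measured. It differs from compound 3 by 1-hydroxy-2-phenoxyethyl in place of hydrogen on a saturated chain carbon bound to an amine nitrogen.

Among the measured compounds shown here, two measured steps bear on this change. Removing a phenyl at the same place gave a 2.5-fold higher number from compound 2 to compound 3 (0.40 log units; beyond the scatter), so putting an aromatic ring back on that chain carbon should move the number the other way. Removing a (dimethylamino)methyl gave only a 1.1-fold lower number from compound 1 to compound 3 (0.05 log units; within the scatter), showing that not every substituent there matters. As far as these compounds go, the entering group carries a phenyl ring, so a modest lowering in this assay is expected, with wide uncertainty because the hydroxyl and the phenoxy linker are untested.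

Compound 4 is therefore estimated to give 700 nM, between 300 nM and 1700 nM. For compound 4 that estimate means a 2.1-fold lower number from compound 3 to compound 4 (0.33 log units; beyond the scatter).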

Compound 4, half-maximal inhibitory concentration: 420 nM
Beside the measured number, compound 4's estimate is 1.7-fold (0.22 log units) above it; the range from low to high includes it.
By their numbers in this assay, from the lowest: compounds 4 and 2 (each within the scatter of the next); then compounds 3 and 1 (each within the scatter of the next).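

In this assay, the 1-hydroxy-2-phenoxyethyl group, with 10 heavy atoms, gives a 3.6-fold lower number from compound 3 to compound 4 (0.55 log units; beyond the scatter), so this saturated chain carbon bound to an amine nitrogen tolerates a far larger group than phenyl. Swapping phenyl for the new group gives a 1.4-fold lower number from compound 2 to compound 4 (0.15 log units; within the scatter), so those two compounds cannot be told apart, and the extra hydroxyl and ether oxygen show no measurable effect beyond what the phenyl compound already gave. The step of a 4.0-fold lower number from compound 1 to compound 4 (0.61 log units; beyond the scatter) confirms that, among the four compounds, both ring-bearing groups sit clear of the (dimethylamino)methyl group, a split that compound 3 also follows.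

No supporting data explain why the ring-bearing groups give lower numbers. Still open, as far as these compounds go, is what the hydroxyl does alone, which a 3-phenoxypropyl chain lacking it would test, and whether a fluorine on the phenoxy ring or a longer chain would lower the number further.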